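Chloro in place of tert-butyl: expected cytotoxicity

The source may report more compounds than this note shows. Statements on the series, on what has been measured and on what is new or still open speak of the compounds shown alone.

Compound 1 `Cc1cc(NC(=O)Nc2ccc(C(C)(C)C)cc2)c2ccccc2n1` and compound 2 `Cc1cc(NC(=O)Nc2cccc([N+](=O)[O-])c2)c2ccccc2n1` share a core and differ only in the group on one six-membered aromatic ring of carbon only. Going by the values given here, in an ADME assay on HepG2 cells (Homo sapiens) for cytotoxicity, with a stated time of 72 h (on this read-out lower numbers stand for an effect already at smaller amounts and higher numbers for an effect only at larger amounts of compound), compound 1 gives 17000 nM, the only number among the values shown so far. In this assay compound 2 reaches only a limit of > 25000 nM, which is not a number; this matches (the limit of > 25000 nM in this assay, at which 1 of the 2 values shown sits). Compound 3 `Cc1cc(NC(=O)Nc2ccc(Cl)cc2)c2ccccc2n1` has not yet been measured in this assay. It differs from compound 1 in one place: chloro in place of tert-butyl on an aromatic carbon. Among the compounds with values here, no measured pair shows this exact change, so the size of the step is open. The step of a 1.3-fold higher number from compound 1 to compound 3 (0.11 log units; within the scatter) is expected to be modest, toward an effect only at somewhat larger amounts, and it may not exceed the usual scatter. For compound 3 the estimate in this assay is 22000 nM, with a range from 9000 nM to 50000 nM.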

Compound 3, half-maximal effective concentration: > 25000 nM
Compound 3 gave a limit, no number (the forecaster's own chance of this, stated with the estimate: 40%); middle value at least 1.1-fold (0.05 log units) away from the limit.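

Going by these compounds alone, this is the first measured step at this position: in this assay, chloro in place of tert-butyl on an aromatic carbon gives an at least 1.4-fold higher number from compound 1 to compound 3 (0.16 log units; that floor lies within the scatter). Compound 3 gives a limit and not a number, so this step has a floor but no known upper end, and that floor alone does not set the two compounds apart. Compound 1 remains the only compound with a true number, and the other two compounds stop at the same upper limit of the read-out: the limit of > 25000 nM in this assay, at which 2 of the 3 values shown sit.

From the compounds shown here alone, how far past that limit compound 3 lies remains open, so the full size of the step cannot be told. Also open, going by these compounds, is how other groups at this position, such as an amine, a carboxylic acid or a longer chain, would read in this assay, and whether any of them would give a number rather than a limit.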